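A few compounds are considered here, and "the series" means these few. Any claim that something is new, unique, unknown or untested is made for them only; others in the source may bear on it.

Compound 1 `COc1ccc(Cl)cc1C(=O)NCCC1CCN(S(=O)(=O)NC(=O)NC2CCCCC2)CC1` and compound 3 `O=C(NC1CCCCC1)NS(=O)(=O)N1CCC(CCNC(=O)c2cc(Cl)cc3cccnc23)CC1` share most of their structure, but their cores differ in one place: 6-chloroquinolin-8-yl in place of 5-chloro-2-methoxyphenyl on a carbonyl carbon. In a functional assay on the whole organism (blood) with Rattus norvegicus as the target, with stated times of 24 h and 1 h, at a dose of 5 mg/kg by the intraperitoneal route (on this read-out higher numbers stand for a stronger effect at the one dose given and lower numbers for a weaker effect), compound 1 gives 25%, while compound 3 gives 52%, and that difference amounts to a number 27 percentage points higher from compound 1 to compound 3 (beyond the scatter). Compound 2 `COc1ccc(Cl)cc1C(=O)NCCC1CCN(S(=O)(=O)NC(=O)NC[C@@H]2C[C@@H]3C=C[C@@H]2C3)CC1` departs from compound 1 in a single place, (a group of 8 heavy atoms (8 carbon; 2 five-membered non-aromatic rings of carbon only) in place of a group of 6 heavy atoms (6 carbon; one six-membered non-aromatic ring of carbon only), on an amide-type nitrogen), and in this assay compound 2 gives 37%, so the change brings a number 12 percentage points higher from compound 1 to compound 2 (beyond the scatter). Compound 4 `O=C(NC[C@@H]1C[C@@H]2C=C[C@@H]1C2)NS(=O)(=O)N1CCC(CCNC(=O)c2cc(Cl)cc3cccnc23)CC1` has not yet been measured in this assay. It stands to compound 3 exactly as compound 2 stands to compound 1: the difference is a group of 8 heavy atoms (8 carbon; 2 five-membered non-aromatic rings of carbon only) in place of a group of 6 heavy atoms (6 carbon; one six-membered non-aromatic ring of carbon only), on an amide-type nitrogen, the same change at the same place, occurring twice among these four compounds. For the measured compounds named here, compound 3 holds the highest number of the three measured so far. Since the same change once gave a number 12 percentage points higher from compound 1 to compound 2 (beyond the scatter), a step of similar size is expected here. The step expected is a number 11 percentage points higher from compound 3 to compound 4 (beyond the scatter). On that basis compound 4 is estimated at 63%, with a likely range from 50% to 76%.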

Compound 4, a percentage reported as activity, at one dose (the size of the read-out at that dose, not a potency): 35%
The estimate for compound 4 lay 28 percentage points above the measured number, outside the stated range (below it).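

Exchanging cyclohexyl for the group of 8 carbon atoms on the amide-type nitrogen gives a number 17 percentage points lower from compound 3 to compound 4 (beyond the scatter), so in this assay the step reverses in direction between the two cores: the same change on two cores in this assay, a number 12 percentage points higher (beyond the scatter) from compound 1 to compound 2 and a number 17 percentage points lower (beyond the scatter) from compound 3 to compound 4, 29 percentage points apart, beyond the scatter of two such steps. The exchange of 5-chloro-2-methoxyphenyl for 6-chloroquinolin-8-yl gives a number 2 percentage points lower from compound 2 to compound 4 (within the scatter), so the gain seen with cyclohexyl on the amide-type nitrogen does not carry over to the other group: the same change on two cores in this assay, a number 27 percentage points higher (beyond the scatter) from compound 1 to compound 3 and a number 2 percentage points lower (within the scatter) from compound 2 to compound 4, 29 percentage points apart, beyond the scatter of two such steps. Among these compounds, then, neither change has a step that can be transferred from one core to the other, but this square alone shows no general rule for the series and, at one dose, says nothing about potency.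

The compounds shown leave open which feature of the entering group goes with the reversal, since its double bond, its ring system and its defined stereocentres all enter together. They also leave open how a phenyl or a cyclopentyl on the same nitrogen would behave on these two cores.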